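From Anilide to Pyridylmethyl Ester in a Vitamin D Series

A few compounds are considered here, and "the series" means these few. Any claim that something is new, unique, unknown or untested is made for them only; others in the source may bear on it.

Compound 1 `CCN(CC)CCCNC(=O)c1ccc(C(CC)(CC)c2ccc(OCC(O)C(C)(C)C)c(C)c2)n1CC`: 66 nM
Compound 2 `CCn1c(C(=O)Nc2cccc(C(F)(F)F)c2)ccc1C(CC)(CC)c1ccc(OCC(O)C(C)(C)C)c(C)c1`: > 50000 nM

In an assay on HL-60 cells for agonist activity at vitamin D3 receptor (Homo sapiens), read by microscopy, with a stated time of 96 h (a lower number here means that less compound is needed, a higher number that more compound is needed for the effect), compound 1 gives 66 nM. For compound 2 this assay reports only a limit, > 50000 nM. The step of an at least 750-fold higher number from compound 1 to compound 2 (2.87 log units; beyond the scatter) is therefore known only through (the limit of > 50000 nM in this assay, at which 1 of the 2 values shown sits), and its true size is open. Compound 3 `CCn1c(C(=O)OCc2ccccn2)ccc1C(CC)(CC)c1ccc(OCC(O)C(C)(C)C)c(C)c1` has not yet been measured; it differs from compound 2 by (pyridin-2-yl)methoxy in place of (3-(trifluoromethyl)phenyl)amino on a carbonyl carbon. Within the data shown here, the one measured step that bears on this change, an at least 750-fold higher number from compound 1 to compound 2 (2.87 log units; beyond the scatter), shows that exchanging the 3-(diethylamino)propyl amide for the 3-(trifluoromethyl)phenyl amide removed activity from the measurable range. Compound 3 gives up the 3-(trifluoromethyl)phenyl group but does not bring back the 3-(diethylamino)propyl chain, so it occupies untested ground between the two measured compounds. Since compound 2 stands at a limit, no number can anchor the step to compound 3; a gain is expected, but its size is uncertain. Compound 3 is estimated at 3000 nM, with a range from 200 nM to 50000 nM. This expected change corresponds to an at least 16-fold lower number from compound 2 to compound 3 (1.22 log units; beyond the scatter), and a limit result remains a real possibility.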

Compound 3, half-maximal effective concentration: > 50000 nM
Compound 3: a limit, no number; the forecaster's own chance of this, stated with the estimate: 35%; middle value at least 16-fold (1.22 log units) from the limit.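

The change to the ester brings an at least 750-fold higher number from compound 1 to compound 3 (2.87 log units; beyond the scatter), so the loss of measurable activity at this carbonyl carbon is not tied to the 3-(trifluoromethyl)phenyl amide alone. Of the two replacements of (3-(diethylamino)propyl)amino shown, which differ in both the linking atom and the aromatic ring, neither returns a number in this assay, and only compound 1 does. The result for compound 3 is a limit and not a number, and the step from compound 2 to compound 3 cannot be read, because of where both values sit: the limit of > 50000 nM in this assay, at which 2 of the 3 values shown sit.

The compounds shown leave open whether the activity of compound 1 goes with its diethylamino amine or with the amide hydrogen, since a 3-(diethylamino)propyl ester or a (pyridin-2-yl)methyl amide on the same carbonyl carbon would separate the two. They also leave open whether a shorter amine chain, or a carboxylic acid at this carbon, would return a measurable value.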